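The compounds below may be only part of what the source reports. "The series", "measured", "known", "first", "only" and "open" are said of these compounds alone.

Working notes on the series. Compound 2 `O=C1CC(c2nc(-c3ccccc3)no2)CN1c1ccc(F)cc1` is the reference point: in an in vitro functional assay on HEK293-A cells for positive allosteric modulation of metabotropic glutamate receptor 5 (Homo sapiens), read by FLIPR and calcium flux (on this read-out lower numbers stand for an effect already at smaller amounts and higher numbers for an effect only at larger amounts of compound), compound 2 gives 58 nM, the lowest number among the two numbers in hand. Compound 3 `Cc1ccc(N2CC(c3nc(-c4ccccc4)no3)CC2=O)cc1` gives 384 nM in this assay. For compound 1 `O=C1CC(c2nc(-c3ccccn3)no2)CN1c1ccc(F)cc1` the read-out is a limit only, > 10000 nM in this assay, namely (the limit of > 10000 nM in this assay, at which 1 of the 3 values shown sits).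

Among the measured compounds shown here, two measured steps touch compound 2. The step of an at least 170-fold lower number from compound 1 to compound 2 (2.23 log units; beyond the scatter) is the larger one, the step of a 6.6-fold higher number from compound 2 to compound 3 (0.82 log units; beyond the scatter) the smaller one.

Compound 4 `O=C1CC(c2nc(-c3cccc(C(F)(F)F)c3)no2)CN1c1ccc(F)cc1` differs from compound 2 by trifluoromethyl in place of hydrogen on an aromatic carbon. Neither measured step places a substituent on this six-membered aromatic ring of carbon only: the step from compound 1 to compound 2 swaps the ring itself, and the step from compound 2 to compound 3 alters the other ring. Both steps show that this scaffold answers to changes at either end, so a shift beyond the scatter in this assay is plausible, but its direction cannot be read from compound 1 or compound 3. The expectation for the step of a 1.9-fold higher number from compound 2 to compound 4 (0.28 log units; within the scatter) is therefore a modest one, with a small loss held somewhat more likely than a gain. Compound 4 is accordingly estimated at 110 nM, within a range from 25 nM to 600 nM.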

Compound 4, half-maximal effective concentration: > 10000 nM
Compound 4: only a limit was reported (the forecaster's own chance of this, stated with the estimate: 8%); at least 90-fold (1.95 log units) between middle value and limit.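

Among the compounds shown here, this is the first substituent placed on the carbon-only aromatic ring, and in this assay it gives an at least 170-fold higher number from compound 2 to compound 4 (2.23 log units; beyond the scatter), whereas the change on the other ring gave a 6.6-fold higher number from compound 2 to compound 3 (0.82 log units; beyond the scatter). Until now only the exchange of this whole ring, an at least 170-fold lower number from compound 1 to compound 2 (2.23 log units; beyond the scatter), had produced a step of that kind; a single trifluoromethyl on the intact ring, meta to a large group, is now shown to be enough to reach the same limit. As far as these compounds go, the read-out for compound 4 is a limit and not a number, so the full size of this step stays unknown, and compound 1 ends at the same place: the limit of > 10000 nM in this assay, at which 2 of the 4 values shown sit.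

The compounds shown leave open whether a smaller group at this carbon, such as fluoro or methyl, or a different one, such as methoxy or a nitrile, would also reach this limit. Also open, from the compounds shown here alone, is whether trifluoromethyl does the same on the other carbons of this ring, so a single compound ties the loss neither to this group nor to this place alone.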